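The source may report more compounds than this note shows. Statements on the series, on what has been measured and on what is new or still open speak of the compounds shown alone.

Compound 3 `COc1cc(OC)c(C(=O)/C=C/c2ccc(Cl)cc2)c(OC)c1` gives 0% in a functional assay on HCT-116 cells (Homo sapiens), read by fluorescence and BrdU incorporation, with a stated time of 48 h, tested at 25 uM; a higher number here means a weaker effect of the compound at the concentration tested, a lower number a stronger effect. Going by the values given here, its nearest neighbour on the numbers so far is compound 2 `COc1cccc(/C=C/C(=O)c2c(OC)cc(OC)cc2OC)c1`, which gives 0.6% in this assay, and the step of a number 0.6 percentage points lower from compound 2 to compound 3 (within the scatter) lies within the scatter. Furthest from it is compound 1 `COc1cc(O)c(C(=O)/C=C/c2ccc(F)cc2)c(OC)c1`, which gives 28% in this assay, a gap beyond the scatter. Compound 4 `COc1cc(OC)c(C(=O)/C=C/c2ccc(Br)cc2)c(OC)c1` differs from compound 3 by bromo in place of chloro on an aromatic carbon, the same difference cut one bond further out reading 4-chlorophenyl to 4-bromophenyl. Among the compounds with values here, no measured step exchanges one halogen for another; the only step on that ring, from compound 2 to compound 3, stayed within the scatter, so no step beyond the scatter is expected here. Compound 4 is estimated at 3%, between 0% and 15%, the expected step being a number 3 percentage points higher from compound 3 to compound 4 (within the scatter).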

Compound 4, a percentage reported as activity, at one concentration (the size of the read-out at that concentration, not a potency): 68%
Compound 4: the middle estimate sits 65 percentage points below what was measured, and the stated range ends below it.
By their numbers in this assay, from the lowest: compounds 3 and 2 (each within the scatter of the next); then compound 1; then compound 4.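

In this assay, the exchange of chloro for bromo on this aromatic carbon, para to a large group, gives a number 68 percentage points higher from compound 3 to compound 4 (beyond the scatter), a much weaker effect from a single halogen change. With 4-bromophenyl in place of 3-methoxyphenyl the result is a number 67.4 percentage points higher from compound 2 to compound 4 (beyond the scatter), whereas 4-chlorophenyl in that place stayed within the scatter, so this site separates the two halogens.

Going by these compounds, whether iodo or an amine on the same carbon would read like chloro or like bromo remains open. Nothing available here explains the gap between chloro and bromo.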